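The compounds below may be only part of what the source reports. "The series", "measured", "known", "first", "only" and "open" are said of these compounds alone.

Compound 1 `Cc1cc(/C=C/C#N)cc(C)c1Oc1cc(NC2CC2)nc(Nc2ccc(C#N)cc2)n1` gives 3000 nM in an ADME assay on MT4 cells (Homo sapiens) for cytotoxicity, read by MTT assay, with a stated time of 5 days; on this read-out lower numbers stand for higher toxicity in this test and higher numbers for lower toxicity in this test.
Compound 2 `C=CCNc1cc(Oc2c(C)cc(/C=C/C#N)cc2C)nc(Nc2ccc(C#N)cc2)n1` gives 3050 nM in this assay.

Compound 2 stands as the higher of the two numbers, but the gap to compound 1 is within the scatter: a 1.0-fold higher number from compound 1 to compound 2 (0.01 log units; within the scatter). Compound 3 `Cc1cc(/C=C/C#N)cc(C)c1Oc1cc(NCCC#N)nc(Nc2ccc(C#N)cc2)n1` differs from compound 2 in one place: cyanomethyl in place of vinyl on a saturated chain carbon bound to a nitrogen on an aromatic ring. Within the data shown here, the one measured step also swapped the group on the same nitrogen and stayed within the scatter, so for the change to compound 3 no step beyond the scatter is expected: a 1.0-fold lower number from compound 2 to compound 3 (0.01 log units; within the scatter). Compound 3 is therefore estimated at 3000 nM, with a range from 1400 nM to 6500 nM.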

Compound 3, half-maximal cytotoxic concentration: 1000 nM
Estimate against measurement, compound 3: 3.0-fold (0.48 log units) above, outside the stated range (below it).
By their numbers in this assay, from the lowest: compound 3; then compounds 1 and 2 (each within the scatter of the next).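

In this assay the group on this nitrogen does matter: allyl and cyclopropyl could not be told apart, but 2-cyanoethyl gives a 3.1-fold lower number from compound 2 to compound 3 (0.48 log units; beyond the scatter) and a 3.0-fold lower number from compound 1 to compound 3 (0.48 log units; beyond the scatter), a shift towards higher toxicity in this test. So a change at this position can move the number beyond the scatter. No measurement shown here accounts for this shift. The compounds shown leave open whether the nitrile itself matters or the chain carrying it, which a plain propyl group could separate. As far as these compounds go, how a longer chain ending in a nitrile or a hydroxyl group would read also remains open.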